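A Halogen Exchange on the Anilide of Compound 2

The source may report more compounds than this note shows. Statements on the series, on what has been measured and on what is new or still open speak of the compounds shown alone.

Two measured compounds share one core and differ in the length of the chain joining the thioether to the amide. Compound 1 `Cn1c(Cc2nn(C)c(=O)c3ccccc23)nnc1SCCCC(=O)Nc1ccc(Cl)cc1Cl` gives 9800 nM in an assay on isolated protein (Mus musculus) for inhibition of IL15-IL15 receptor (Homo sapiens), read by resazurin assay, with stated times of 30 min and 2.5 days; on this read-out higher numbers stand for weaker inhibition and lower numbers for stronger inhibition. Compound 2 `Cn1c(Cc2nn(C)c(=O)c3ccccc23)nnc1SCCCCCCCC(=O)Nc1ccc(Cl)cc1Cl` gives 1900 nM in this assay, the lowest of the two numbers shown, and its gap to compound 1 lies beyond the usual scatter.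

Compound 3 `Cn1c(Cc2nn(C)c(=O)c3ccccc23)nnc1SCCCCCCCC(=O)Nc1ccc(Br)cc1Br` has not yet been measured. It differs from compound 2 by 2,4-dibromophenyl in place of 2,4-dichlorophenyl on an amide-type nitrogen. Going by the values given here, no measured pair in this set shows that exchange, so the expectation rests on compound 2 alone.

Compound 3 is expected to give about 1500 nM in this assay, with a range from 600 nM to 4000 nM. The estimate implies a step of a 1.3-fold lower number from compound 2 to compound 3 (0.10 log units; within the scatter), an expected change that stays within the scatter of repeated measurements, with no clear direction.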

Compound 3, half-maximal inhibitory concentration: 1500 nM
The estimate for compound 3 equals the measured number at the digits printed; measured number inside the range.
By their numbers in this assay, from the lowest: compounds 3 and 2 (each within the scatter of the next); then compound 1.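

In this assay the exchange of 2,4-dichlorophenyl for 2,4-dibromophenyl on the amide-type nitrogen gives a 1.3-fold lower number from compound 2 to compound 3 (0.10 log units; within the scatter) and so leaves the number unmoved beyond the scatter. Compounds 1 and 2 differ only in the chain and say nothing about the anilide ring, whereas this pair shows that, on the chain of compound 2, the two dihalophenyl groups cannot be told apart on this read-out. No measurement at hand bears on why the two groups read alike.

Going by these compounds, it remains open whether the same holds on the shorter chain of compound 1, and whether a longer chain would lower the number further. Also open, on these data alone, is whether the halogens matter at all, which unsubstituted phenyl, 2,4-difluorophenyl or 2,4-dimethylphenyl on the same nitrogen could show.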